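From propanoyl to a 2-fluorophenyl carbonyl group

The compounds below may be only part of what the source reports. "The series", "measured", "known", "first", "only" and "open" are said of these compounds alone.

Among the compounds with values here, in a functional assay on A549 cells (Homo sapiens) for cytotoxicity, read by MTT assay, with a stated time of 72 h (a higher number here means a weaker inhibitor, a lower number a stronger inhibitor), compound 1 `CCN1C/C(=C\c2cc(OC)c(OC)c(OC)c2)C(=O)/C(=C/c2cc(OC)c(OC)c(OC)c2)C1` gives 4200 nM and compound 2 `CCC(=O)N1C/C(=C\c2cc(OC)c(OC)c(OC)c2)C(=O)/C(=C/c2cc(OC)c(OC)c(OC)c2)C1` gives 800 nM, so compound 2 holds the lower of the two numbers measured so far. Compound 3 `COc1cc(/C=C2\CN(C(=O)c3ccccc3F)C/C(=C\c3cc(OC)c(OC)c(OC)c3)C2=O)cc(OC)c1OC` has the same core as compound 2, with 2-fluorophenyl in place of ethyl on a carbonyl carbon. The carbonyl carbon and its amide-type nitrogen in a ring stay unchanged.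

Within the data shown here, only one measured step bears on this change: a 5.3-fold lower number from compound 1 to compound 2 (0.72 log units; beyond the scatter), a modest step that came with propanoyl in place of ethyl on an amine nitrogen in a ring. That step is a different change, and it gives only indirect guidance. Among the measured compounds shown here, no measured compound carries an aromatic ring on the carbonyl carbon, so the data offer no direction for the new step. No shift beyond the scatter is therefore expected in this assay, although the uncertainty is wide. The expected change is a 1.1-fold lower number from compound 2 to compound 3 (0.06 log units; within the scatter). For compound 3, the estimated value is 700 nM, with an expected range of 200 nM to 2500 nM.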

Compound 3, half-maximal inhibitory concentration: 700 nM
For compound 3 middle estimate and measured number coincide at the digits printed; measured number inside the range.
By their numbers in this assay, from the lowest: compounds 3 and 2 (each within the scatter of the next); then compound 1.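

The carbonyl carbon on the ring nitrogen accepts a much larger group with an aromatic ring without a shift in this assay, where the swap of ethyl for 2-fluorophenyl gives a 1.1-fold lower number from compound 2 to compound 3 (0.06 log units; within the scatter) and leaves compound 2 and compound 3 within the scatter of each other. The advantage over the ethyl on the amine nitrogen in compound 1 therefore holds for an aromatic acyl group as well as for propanoyl, with a 6.0-fold lower number from compound 1 to compound 3 (0.78 log units; beyond the scatter) as the step for the aromatic case, and among these three compounds none goes against that reading. No measurement at hand accounts for either step.

Open, as far as these compounds go, is what the fluorine contributes, since a plain phenyl on the same carbonyl carbon would separate the ring from the halogen. Also open, from the compounds shown here alone, is whether this level in this assay holds for a longer alkyl chain on the carbonyl carbon, or for an acyl group ending in an amine or a carboxylic acid.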